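This account rests on a few compounds, and the source may have more. Where it says the series, first, only, none or still open, it means among the compounds named here.

Measured so far in an in vitro assay on Sf21 cells for inhibition of high affinity 3',5'-cyclic-AMP phosphodiesterase 7A (Homo sapiens); a higher number here means a weaker inhibitor, a lower number a stronger inhibitor:
- compound 1 `CNc1nc(NC2(C#N)CCCCC2)nc(N2CCCC2)n1`: > 5000 nM
- compound 2 `CNc1nc(Cl)nc(NC2(C#N)CCCCC2)n1`: 1070 nM
- compound 3 `CNc1nc(NC2(C#N)CCCCC2)nc(SC)n1`: 46 nM

The value of compound 1 is a limit of this assay, not a number. Compound 3 gives the lowest number shown; its nearest neighbour is compound 2, from which the step is a 23-fold lower number from compound 2 to compound 3 (1.37 log units; beyond the scatter). Compound 4 `CNc1nc(NC2(C#N)CCCCC2)nc(-n2cnc(C)n2)n1` is not yet measured; it differs from compound 3 by 3-methyl-1H-1,2,4-triazol-1-yl in place of methylsulfanyl on an aromatic carbon. Within the data shown here, two measured steps bear on this position: an at least 4.6-fold lower number from compound 1 to compound 2 (0.66 log units; beyond the scatter) and an at least 100-fold lower number from compound 1 to compound 3 (2.03 log units; beyond the scatter). Both show that a ring at this position gives the weakest result shown, and that the methylsulfanyl group gives the strongest. A new ring at the same place is therefore expected to raise the number, by a 7.6-fold higher number from compound 3 to compound 4 (0.88 log units; beyond the scatter). Compound 4 is estimated at 350 nM, within 50 nM to 3000 nM.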

Compound 4, half-maximal inhibitory concentration: > 5000 nM
Compound 4: no number, only a limit (the forecaster's own chance of this, stated with the estimate: 15%); at least 14-fold (1.15 log units) between middle value and limit.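

Placing 3-methyl-1H-1,2,4-triazol-1-yl on this aromatic carbon gives an at least 100-fold higher number from compound 3 to compound 4 (2.03 log units; beyond the scatter), and comparison with chloro gives an at least 4.6-fold higher number from compound 2 to compound 4 (0.66 log units; beyond the scatter). Like pyrrolidin-1-yl, this aromatic ring leaves its compound without a measured number, so the poor result of compound 1 is not confined to one kind of ring. How compound 1 and compound 4 compare cannot be read, since both values are limits and not numbers: the limit of > 5000 nM in this assay, at which 2 of the 4 values shown sit.

As far as these compounds go, what a methoxy group, a dimethylamino group or a longer sulfur chain such as ethylsulfanyl would give stays open. So does whether any smaller ring could work here.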